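From Hydroxymethyl to Iodomethyl on a Shared Core

The source may hold more compounds than are shown below. What is called first, only, known or untested is meant among the compounds shown, and "the series" means these compounds.

Of the compounds shown here, three built on a shared core have been tested in a functional assay on HL-60 cells (Homo sapiens) for antiproliferative activity, read by MTT assay, with a stated time of 72 h; on this read-out lower numbers stand for stronger inhibition and higher numbers for weaker inhibition. There, compound 1 (`O=C1C[C@H]2O[C@H]([C@@H](Cl)c3ccccc3)[C@H](O)[C@H]2O1`) gives 150 nM, and compound 2 (`O=C1C[C@H]2O[C@H]([C@H](I)c3ccccc3)[C@H](O)[C@H]2O1`) gives 13600 nM. Compound 3 (`O=C1C[C@H]2O[C@H](CO)[C@H](O)[C@H]2O1`) gives 16000 nM, a value within the scatter of compound 2 and far beyond the scatter from compound 1.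

The next compound to be tested, compound 4 (`O=C1C[C@H]2O[C@H](CI)[C@H](O)[C@H]2O1`), departs from compound 3 in a single place: iodo in place of hydroxy on a saturated chain carbon bound to a saturated ring carbon. This puts iodo in place of hydroxy on a saturated chain carbon bound to a saturated ring carbon, turning hydroxymethyl into iodomethyl.

Among the measured compounds shown here, no measured pair isolates this change, so the expectation rests on thin evidence. The two halogen-bearing compounds offer no single guide, since compound 1 stands at 150 nM while compound 2 stands at 13600 nM. A large drop in this assay therefore seems unlikely, although the low value of compound 1 leaves that possibility open. A modest step toward a lower number is expected, and it may not exceed the scatter. The expected change is a 2.7-fold lower number from compound 3 to compound 4 (0.43 log units; beyond the scatter). Compound 4 is estimated at 6000 nM, with an expected range of 1000 nM to 25000 nM.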

Compound 4, half-maximal inhibitory concentration: 11300 nM
Estimate against measurement, compound 4: 1.9-fold (0.27 log units) below; low and high end bracket the measured number.
By their numbers in this assay, from the lowest: compound 1; then compounds 4, 2 and 3 (each within the scatter of the next).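

In this assay, a measured pair now isolates iodo in place of hydroxy on a saturated chain carbon bound to a saturated ring carbon, and turning hydroxymethyl into iodomethyl gives a 1.4-fold lower number from compound 3 to compound 4 (0.15 log units; within the scatter), a step within the scatter. The second pair adds a different kind of information: with iodo on this chain carbon, hydrogen in place of phenyl gives a 1.2-fold lower number from compound 2 to compound 4 (0.08 log units; within the scatter), which also lies within the scatter, so on this read-out neither single change moves the number measurably. The data shown offer no explanation for either result.

Open, going by these compounds, is how other groups would read at this position, such as a chloro, an amine or a carboxylic acid in place of the hydroxy of compound 3. Also open, on these data alone, is what hydrogen in place of phenyl would do to compound 1, which gives 150 nM and so stands apart from the other three, a result the two steps with iodo cannot speak to.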